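Shortening the Ether Side Chain: From Compound 2 to Compound 4

The source may hold more compounds than are shown below. What is called first, only, known or untested is meant among the compounds shown, and "the series" means these compounds.

Of the compounds shown here, three built on one shared core have been tested in a functional assay on KBVIN cells (Homo sapiens) for antiproliferative activity, read by sulforhodamine B assay, with a stated time of 3 days; a higher number here means that more compound is needed for the effect, a lower number that less compound is needed. Compound 1 `CCCC1(CC=C(C)C)C(=O)C(C(=O)/C=C/c2ccccc2)=C(O)C(CCC)(CCC)C1=O` gives 7.3 uM. Compound 2 `CCCC1=C(OCC(C)C)C(CCC)(CCC)C(=O)/C(=C(O)\C=C\c2ccccc2)C1=O` gives 4.1 uM, the lowest of the three numbers, though its gap to compound 1 lies within the usual scatter, so those two cannot be ranked against each other. Compound 3 `CCCCC1=C(OC)C(CCCC)(CCCC)C(=O)/C(=C(O)\C=C\c2ccccc2)C1=O` gives 8.6 uM, a number that sits beyond the scatter above that of compound 2.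

Compound 4 `CCCC1=C(OC)C(CCC)(CCC)C(=O)/C(=C(O)\C=C\c2ccccc2)C1=O` has not yet been measured. It differs from compound 2 in one place: hydrogen in place of isopropyl on a saturated chain carbon bound to an oxygen on an unsaturated carbon. Cut one bond further out, the change reads isobutoxy to methoxy. Within the data shown here, no measured pair shows this change on its own; compound 3 shares the methoxy group of compound 4 but differs elsewhere in its core, so its value offers only a hint. A small move toward a higher number, or none beyond the scatter, is the expectation. Compound 4 is expected to give 6 uM, with a range from 3 uM to 12 uM. The expected step from compound 2 to compound 4 is a 1.5-fold higher number from compound 2 to compound 4 (0.17 log units; within the scatter), within the scatter.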

Compound 4, concentration for half-maximal effect: 3.4 uM
Compound 4: middle estimate off by 1.8-fold (0.25 log units), on the high side; the measured number falls inside the stated range.
By their numbers in this assay, from the lowest: compounds 4, 2, 1 and 3 (each within the scatter of the next, the first and the last beyond it).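

Among these compounds, compound 4 gives the first direct reading of isobutoxy to methoxy on this core: a 1.2-fold lower number from compound 2 to compound 4 (0.08 log units; within the scatter) in this assay separates the two compounds by no more than the usual scatter. Compound 3 could offer only a hint, as it differs elsewhere too, whereas this pair shows that the isopropyl, with its 3 carbon atoms, can give way to hydrogen on this saturated chain carbon without a change that can be read. Nothing available here explains this result.

Open, from the compounds shown here alone, is whether a longer chain, or one ending in an amine or a carboxylic acid, would also stay within the scatter of compound 2 at this place. Also open, going by these compounds, is whether isobutoxy to methoxy would read the same on the core of compound 3.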